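The compounds below may be only part of what the source reports. "The series", "measured", "known", "first", "only" and "open" are said of these compounds alone.

Values in a functional assay on RKO cells (Homo sapiens) for inhibition, read by MTT assay, with a stated time of 48 h (on this read-out higher numbers stand for weaker inhibition and lower numbers for stronger inhibition), so far:
- compound 1 `COc1ccc(N(C)c2nc(C)nc3ccccc23)cc1OCCC[Se]C#N` gives 799 nM
- compound 2 `COc1ccc(N(C)c2nc(C)nc3ccccc23)cc1C(=O)OCCCC[Se]C#N` gives 1020 nM
- compound 3 `COc1ccc(N(C)c2nc(C)nc3ccccc23)cc1OCCN` gives 343 nM

Compound 3 has the lowest number of the three, and both steps that reach it lie beyond the scatter. The unmeasured compound 4 `COc1ccc(N(C)c2nc(C)nc3ccccc23)cc1OCCCCC[Se]C#N` loses the amino of compound 3, and the change is a group of 6 heavy atoms (4 carbon, 1 nitrogen, 1 selenium; no ring) in place of one nitrogen atom, on a saturated chain carbon, two bonds along the chain from an oxygen on an aromatic ring in the same place.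

The closest evidence is a 2.3-fold lower number from compound 1 to compound 3 (0.37 log units; beyond the scatter) and it is modest. It reads as this change in reverse, with a selenium-bearing group of another size. The step of a 3.0-fold lower number from compound 2 to compound 3 (0.47 log units; beyond the scatter) is also modest, while a 1.3-fold higher number from compound 1 to compound 2 (0.11 log units; within the scatter) leaves the two selenium-bearing compounds unseparated. Among the measured compounds shown here, no measured pair varies chain length alone, so no separate allowance is made for it.

A modest rise in this assay is therefore expected, as the reverse of a 2.3-fold lower number from compound 1 to compound 3 (0.37 log units; beyond the scatter) suggests. The estimated step is a 2.3-fold higher number from compound 3 to compound 4 (0.37 log units; beyond the scatter) for this exchange. Compound 4 is estimated at 800 nM in this read-out, with an expected range from 380 nM to 1700 nM for repeat measurements.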

Compound 4, half-maximal inhibitory concentration: 3560 nM
For compound 4 the middle estimate is 4.5-fold (0.65 log units) below the measured one, and the stated range ends below it.
By their numbers in this assay, from the lowest: compound 3; then compounds 1 and 2 (each within the scatter of the next); then compound 4.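

In this assay, among the compounds shown here, the exchange of the amino for the group of 6 heavy atoms on this saturated chain carbon is a large step (a 10-fold higher number from compound 3 to compound 4 (1.02 log units; beyond the scatter)), larger than any step among the earlier compounds. Chain length now matters on its own, since a longer chain, with the selenium and nitrile kept, gives a clear rise (a 4.5-fold higher number from compound 1 to compound 4 (0.65 log units; beyond the scatter)), and compound 4 also separates from compound 2 (a 3.5-fold higher number from compound 2 to compound 4 (0.54 log units; beyond the scatter)), which the earlier data left unseparated from compound 1. No measurement here gives a reason for these steps.

Going by these compounds, whether the rise continues with a longer chain ending in the same selenium and nitrile remains open. Also open, on these data alone, is whether the amino keeps its lower number on a longer chain, and how a carboxylic acid or a tertiary amine would read at the same place.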